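Swapping the aryl group on a shared core

This account rests on a few compounds, and the source may have more. Where it says the series, first, only, none or still open, it means among the compounds named here.

Three compounds share one core and differ only in the aromatic ring attached to it. Compound 1 carries a 4-isopropylphenyl group `Cc1ccc(Nc2nc(SCc3cn(Cc4ccccc4Cl)nn3)nc(-c3ccc(C(C)C)cc3)c2C#N)cc1`, compound 2 a 4-methylphenyl group `Cc1ccc(Nc2nc(SCc3cn(Cc4ccccc4Cl)nn3)nc(-c3ccc(C)cc3)c2C#N)cc1`, and compound 3 a 3,4,5-trimethoxyphenyl group `COc1cc(-c2nc(SCc3cn(Cc4ccccc4Cl)nn3)nc(Nc3ccc(C)cc3)c2C#N)cc(OC)c1OC`. Compound 4, still to be tested, carries a 4-chlorophenyl group `Cc1ccc(Nc2nc(SCc3cn(Cc4ccccc4Cl)nn3)nc(-c3ccc(Cl)cc3)c2C#N)cc1`.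

In a functional assay on MGC-803 cells (Homo sapiens) for inhibition, read by MTT assay, with a stated time of 72 h (on this read-out lower numbers stand for stronger inhibition and higher numbers for weaker inhibition), compound 1 reaches only the limit of the assay, > 64000 nM, which is not a measured number. Compound 2 gives 24400 nM. Compound 3 gives 30800 nM, which sits within the usual scatter of compound 2.

Within the data shown here, the steps so far: an at least 2.6-fold lower number from compound 1 to compound 2 (0.41 log units; beyond the scatter), an at least 2.0-fold lower number from compound 1 to compound 3 (0.31 log units; beyond the scatter), and a 1.3-fold higher number from compound 2 to compound 3 (0.10 log units; within the scatter).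

The change studied here is 4-chlorophenyl in place of 3,4,5-trimethoxyphenyl on an aromatic carbon. Among the measured compounds shown here, no measured step involves a 4-chlorophenyl group, so the guide is indirect: the two aryl groups for which numbers exist lie within the scatter of each other, and only the 4-isopropylphenyl group stays at the limit. The 4-chlorophenyl group is expected to land in the same range as compounds 2 and 3, giving an expected 1.2-fold lower number from compound 3 to compound 4 (0.09 log units; within the scatter). Compound 4 is therefore estimated at 25000 nM, with a range from 10000 nM to 60000 nM.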

Compound 4, half-maximal inhibitory concentration: 18500 nM
For compound 4 the middle estimate is 1.4-fold (0.13 log units) above the measured one, within the range that was stated.
By their numbers in this assay, from the lowest: compounds 4, 2 and 3 (each within the scatter of the next). At a limit, above all of these: compound 1.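

Swapping the 3,4,5-trimethoxyphenyl group, with its 12 heavy atoms and 3 hydrogen-bond acceptors, for 4-chlorophenyl, with 7 heavy atoms and no acceptors, gives a 1.7-fold lower number from compound 3 to compound 4 (0.22 log units; within the scatter) in this assay, so at this position on the shared core those acceptors are not needed to hold this level of inhibition. Chloro in place of methyl gives a 1.3-fold lower number from compound 2 to compound 4 (0.12 log units; within the scatter), which means that compounds 2, 3 and 4 cannot be told apart here despite their quite different aryl groups. Compound 1 is the only one that stands apart, and the step to the chloro group, an at least 3.4-fold lower number from compound 1 to compound 4 (0.53 log units; beyond the scatter), gives only a minimum size for the difference, since compound 1 has no exact number: the limit of > 64000 nM in this assay, at which 1 of the 4 values shown sits.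

A 4-ethylphenyl group would help show whether the loss seen with 4-isopropylphenyl begins with a slightly longer chain or only at the branched group. From the compounds shown here alone, it also remains open whether anything at this position can move the number beyond the scatter in the favourable direction, for example a ring bearing an amine or a carboxylic acid in place of the chlorine.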